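Chloro for Methoxy Beneath a Tolerance Ceiling

The source may hold more compounds than are shown below. What is called first, only, known or untested is meant among the compounds shown, and "the series" means these compounds.

Compound 1 `COc1ccccc1-c1cnc(NC(=O)c2ccc(F)cc2)n1C`: in a toxicity assay on THP-1 cells (Homo sapiens) for inhibition (a lower number here means that less compound is tolerated, a higher number that more compound is tolerated), compound 1 gives > 100000 nM, a limit of the assay rather than a number.
Compound 2 `COc1ccc(-c2cnc(NC(=O)c3ccc(F)cc3)[nH]2)cc1`: compound 2 gives > 100000 nM, again a limit.
Compound 3 `COc1ccc(-c2cnc(NC(=O)c3ccccc3)n2C)cc1`: compound 3 gives > 100000 nM, also a limit.

For the measured compounds named here, compound 1 therefore stands at the limit of > 100000 nM in this assay, at which 3 of the 3 values shown sit, where every measured value sits, so no step between measured compounds can be weighed. Compound 4 `Cn1c(-c2ccccc2Cl)cnc1NC(=O)c1ccc(F)cc1` differs from compound 1 by chloro in place of methoxy on an aromatic carbon. With all three measured values resting at that limit, the step expected in this assay, a number no higher from compound 1 to compound 4 (the limit leaves the size open), is none beyond the scatter. Compound 4 is estimated at 100000 nM, between 50000 nM and 200000 nM, and the assay is expected most likely to report only a limit again.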

Compound 4, half-maximal cytotoxic concentration: > 50000 nM
Compound 4 was reported as a limit (the forecaster's own chance of this, stated with the estimate: 80%); the middle value does not contradict the limit.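

For the compounds shown here, compound 1 and compound 4 are both reported only as limits, so no step between them can be read. The compounds shown leave open at what concentration, if any, each becomes toxic to these cells.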